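The compounds below may be only part of what the source reports. "The series", "measured", "known", "first", "only" and "open" are said of these compounds alone.

Measured so far:
- compound 1, `FC(F)(F)c1cc(COCC2(c3ccccc3)CCC(N3CCCC3)CC2)cc(C(F)(F)F)c1`: 120 nM
- compound 2, `FC(F)(F)c1cc(COCC2(c3ccccc3)CCC(N3CCCCC3)C2)cc(C(F)(F)F)c1`: 4.7 nM

In an assay on isolated protein for antagonist activity at Substance-P receptor (Homo sapiens) (on this read-out lower numbers stand for stronger inhibition and higher numbers for weaker inhibition), compound 2 gives 4.7 nM, the lowest of the two numbers measured; compound 1 gives 120 nM, a number higher by an amount beyond the scatter. The two compounds differ in more than one place, so no single step can be read from that pair.

Compound 3, `CN(C)C1CCC(COCc2cc(C(F)(F)F)cc(C(F)(F)F)c2)(c2ccccc2)C1`, has not been measured in this assay. It differs from compound 2 by dimethylamino in place of piperidin-1-yl on a saturated ring carbon; in words, dimethylamino in place of piperidin-1-yl on a saturated ring carbon. Among the compounds with values here, no measured pair isolates such a change, so the expectation rests on the position of compound 2 alone. A moderate weakening is expected, with the step from compound 2 to compound 3 estimated at a 2.6-fold higher number from compound 2 to compound 3 (0.41 log units; beyond the scatter), somewhat beyond the scatter in the direction of a higher number. For compound 3 the estimate in this assay is 12 nM, with a range from 3 nM to 50 nM.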

Compound 3, half-maximal inhibitory concentration: 8 nM
Estimate against measurement, compound 3: 1.5-fold (0.18 log units) above; low and high end bracket the measured number.
By their numbers in this assay, from the lowest: compounds 2 and 3 (each within the scatter of the next); then compound 1.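

In this assay dimethylamino in place of piperidin-1-yl on a saturated ring carbon gives a 1.7-fold higher number from compound 2 to compound 3 (0.23 log units; within the scatter) and so shows that, at this position, the six-membered ring of piperidin-1-yl can give way to an open amine with fewer heavy atoms without a step beyond the scatter. Within the data shown here, compound 1 and compound 2 differ in more than one place, so this is the first change that can be read on its own. Nothing at hand explains this result.

Open, going by these compounds, is whether morpholin-4-yl, methylamino or a bare primary amine on the same carbon would also stay within the scatter of compound 2. Also open, on these data alone, is whether dimethylamino in place of the amine of compound 1 would read the same way on that core.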